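Two Carbamate Aldehydes at the Assay Ceiling, One Analogue Pending

The compounds below may be only part of what the source reports. "The series", "measured", "known", "first", "only" and "open" are said of these compounds alone.

Compound 1, `O=C[C@H](C[C@@H]1CCNC1=O)NC(=O)[C@H](CC1CCCCC1)NC(=O)OCc1ccccc1`: > 200000 nM
Compound 2, `CC(C)C[C@H](NC(=O)OCc1cccc(F)c1)C(=O)N[C@H](C=O)C[C@@H]1CCNC1=O`: > 200000 nM

In an ADME assay on Vero C1008 cells (Chlorocebus sabaeus) for cytotoxicity, read by luminescence and CellTiter-Glo, with a stated time of 24 h (a higher number here means that more compound is tolerated, a lower number that less compound is tolerated), compound 2 gives > 200000 nM, which is a limit of the assay rather than a number. Compound 1 likewise gives only a limit, > 200000 nM. Both therefore sit at the limit of > 200000 nM in this assay, at which 2 of the 2 values shown sit, so nothing separates them. Compound 3, `CC(C)C[C@H](NC(=O)O[C@@H](C)c1ccccc1)C(=O)N[C@H](C=O)C[C@@H]1CCNC1=O`, has not yet been measured. It differs from compound 2 by 1-phenylethyl in place of 3-fluorobenzyl on an oxygen next to a carbonyl group. Among the measured compounds shown here, no measured step is available, so in this assay no step beyond the usual scatter is expected in either direction. Compound 3 is expected at 200000 nM, between 100000 nM and 400000 nM. The expected step is a number no higher from compound 2 to compound 3 (the limit leaves the size open).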

Compound 3, half-maximal cytotoxic concentration: > 200000 nM
Compound 3: only a limit was reported; the forecaster's own chance of this, stated with the estimate: 85%; the middle value lies on the limit itself.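

Compound 3 gives > 200000 nM, which is a limit and not a number, so no step can be read between compound 2 and compound 3: the limit of > 200000 nM in this assay, at which 3 of the 3 values shown sit. As far as these compounds go, whether 1-phenylethyl and 3-fluorobenzyl differ at all in this assay stays open, as does the actual tolerated concentration of all three compounds.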